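This account rests on a few compounds, and the source may have more. Where it says the series, first, only, none or still open, it means among the compounds named here.

Two compounds of this series have numbers in a functional assay on cells (Cancer cell lines, Homo sapiens) for cytotoxicity, with a stated time of 48 h (on this read-out higher numbers stand for weaker inhibition of growth and lower numbers for stronger inhibition of growth), so far. Compound 1 `COc1c(/C=C2/C(=O)Nc3ccc(Cl)cc32)c2ccccc2n1-c1ccccc1` gives 13800 nM in this assay. Compound 2 `COc1cc2c(/C=C3/C(=O)Nc4ccc(O)cc43)c(Cl)n(Cc3cc(OC)c(OC)c(OC)c3)c2cc1C` gives 34700 nM in this assay, the higher of the two numbers; the gap to compound 1 lies beyond the scatter, but the two structures differ in several places and no single step can be read from them. Compound 3 `COc1cc2c(/C=C3/C(=O)Nc4ccc(Cl)cc43)c(Cl)n(Cc3cc(OC)c(OC)c(OC)c3)c2cc1C` is the next compound to be measured. It differs from compound 2 by chloro in place of hydroxy on an aromatic carbon, and the same chloro is carried at that carbon by compound 1, whose number in this assay is 13800 nM. A step toward a lower number is therefore expected, of modest size and near the edge of the scatter, shown as a 1.8-fold lower number from compound 2 to compound 3 (0.26 log units; within the scatter). For compound 3 the estimate in this assay is 19000 nM, within a range from 8000 nM to 45000 nM.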

Compound 3, concentration for total growth inhibition: 5500 nM
For compound 3 the middle estimate is 3.5-fold (0.54 log units) above the measured one; the whole stated range lies above it.
By their numbers in this assay, from the lowest: compound 3; then compound 1; then compound 2.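

Chloro in place of hydroxy on this aromatic carbon, meta to a fused ring and para to a fused ring, gives the first single-place comparison in the series: in this assay the change is a 6.3-fold lower number from compound 2 to compound 3 (0.80 log units; beyond the scatter) and lies beyond the scatter. The earlier pair differed in several places, whereas this exchange shows that the read-out responds to the group at this carbon while the rest of the molecule stays unchanged. No measurement among the data accounts for the size or direction of this step.

Only hydroxy and chloro are shown at this carbon, so the outcome with an amine or a carboxylic acid there remains open. Whether the same exchange would move the number similarly on the core of compound 1 also cannot be read from the compounds shown.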